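This account rests on a few compounds, and the source may have more. Where it says the series, first, only, none or still open, it means among the compounds named here.

Measured compounds:
- compound 1 `C=CCc1c(O)cc(O)c(C(=O)/C=C/c2ccc(O)cc2)c1O` — in a functional assay on aorta (Rattus norvegicus, strain Sprague-Dawley) for inhibition, with a stated time of 20 min (a lower number here means a smaller maximal response, a higher number a larger maximal response), compound 1 gives 108%
- compound 2 `C=CCc1c(O)ccc(C(=O)/C=C/c2ccc(O)cc2)c1O` — compound 2 gives 73.4%
- compound 3 `C=CCc1c(O)cc(O)c2c1OC(c1ccc(O)cc1)CC2=O` — compound 3 gives 9.86%

Compound 3 gives the lowest of the three numbers, and its gaps to compound 2 and to compound 1 both lie beyond the scatter. Among the measured compounds shown here, the single change from compound 1 to compound 2, (hydrogen in place of hydroxy on an aromatic carbon), produced a large step, a number 34.6 percentage points lower from compound 1 to compound 2 (beyond the scatter). Compound 1 and compound 3 have the same atoms joined differently; the difference between the two cores is not broken down here.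

Compound 4 `C=CCc1c(O)ccc2c1OC(c1ccc(O)cc1)CC2=O` has not been measured in this assay. It arises from compound 3 by hydrogen in place of hydroxy on an aromatic carbon. This is the same kind of change as that from compound 1 to compound 2, though its surroundings differ: here the carbon is ortho to a fused ring, meta to a fused ring and meta to one hydroxy group, whereas in compound 1 it is ortho to a large group and meta to two hydroxy groups; in both cases it is para to an allyl group.

Because compound 3 already gives 9.86%, there is little room for a fall as large as a number 34.6 percentage points lower from compound 1 to compound 2 (beyond the scatter). The expected step is a number 3.9 percentage points lower from compound 3 to compound 4 (within the scatter). For compound 4 the expected value is 6%, estimated to lie between 0% and 25%.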

Compound 4, largest response reached (Emax), in percent of the reference or control that the assay uses: 87.2%
For compound 4 the middle estimate is 81.2 percentage points below the measured one; measured number outside the range, above it.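

In this assay, putting hydrogen in place of hydroxy on an aromatic carbon of the second core gives a number 77.3 percentage points higher from compound 3 to compound 4 (beyond the scatter), so the change did not carry over from the core of compound 1 to the core of compound 3 in either direction or size. Set side by side, the two steps disagree: the same change on two cores in this assay, a number 34.6 percentage points lower (beyond the scatter) from compound 1 to compound 2 and a number 77.3 percentage points higher (beyond the scatter) from compound 3 to compound 4, 111.9 percentage points apart, beyond the scatter of two such steps This shows that, in this series, the step read on one core gave no guide to the step on the other, but with a single pair on each core it does not show which difference between the cores lies behind the disagreement, nor how the change would behave on any further core.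

As far as these compounds go, all four compounds carry the allyl group, so it remains open whether the disagreement persists with a longer chain in its place. From the compounds shown here alone, it also remains open what a methoxy group or a fluorine would do on each core at the carbon where hydroxy and hydrogen were exchanged.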